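The source may hold more compounds than are shown below. What is called first, only, known or untested is meant among the compounds shown, and "the series" means these compounds.

Compound 1 `COc1cc(-c2nnc3c(OC)cc(-c4ccc5[nH]ccc5c4)cn23)cc(OC)c1OC`: 80 nM
Compound 2 `COc1cc(-c2nnc3c(OC)cc(-c4ccc5[nH]cc(C=O)c5c4)cn23)cc(OC)c1OC`: > 10000 nM (a limit of the assay, not a number)
Compound 3 `COc1cc(-c2nnc3c(OC)cc(-c4ccc5c(ccn5C)c4)cn23)cc(OC)c1OC`: 49 nM

All three compounds were tested in a functional assay on MCF7 cells (Homo sapiens) for antiproliferative activity, read by MTT assay, with a stated time of 48 h; a lower number here means a stronger inhibitor, a higher number a weaker inhibitor. Compound 3, at 49 nM, stands level with compound 1, as the step shows: a 1.6-fold lower number from compound 1 to compound 3 (0.21 log units; within the scatter). Compound 2 lies far from both, and the step to compound 3 is large: an at least 200-fold lower number from compound 2 to compound 3 (2.30 log units; beyond the scatter).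

Compound 4 `COc1cc(-c2nnc3c(OC4CC4)cc(-c4ccc5c(ccn5C)c4)cn23)cc(OC)c1OC` differs from compound 3 in a single group: cyclopropyl in place of methyl on an oxygen on an aromatic ring. Put simply, methoxy becomes cyclopropyloxy.

For the measured compounds named here, no measured step touches that oxygen, so the evidence is only indirect. Methyl in place of hydrogen on an aromatic nitrogen gave a 1.6-fold lower number from compound 1 to compound 3 (0.21 log units; within the scatter). Formyl in place of hydrogen on an aromatic carbon gave an at least 120-fold higher number from compound 1 to compound 2 (2.09 log units; beyond the scatter). These two steps show that a single added group can change little or a great deal in this series, but neither one sets a direction for the new change. A small rise in the number is expected, with a wide margin on the high side. The expected step is a 1.8-fold higher number from compound 3 to compound 4 (0.26 log units; within the scatter). For compound 4 the estimated value is 90 nM, with an expected range of 25 nM to 400 nM.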

Compound 4, half-maximal inhibitory concentration: 118 nM
The estimate for compound 4 lay 1.3-fold (0.12 log units) below the measured number; measured number inside the range.
By their numbers in this assay, from the lowest: compounds 3, 1 and 4 (each within the scatter of the next, the first and the last beyond it). At a limit, above all of these: compound 2.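

For the compounds shown here, this is the only measured change at the oxygen on an aromatic ring, and in this assay putting cyclopropyl in place of methyl gives a 2.4-fold higher number from compound 3 to compound 4 (0.38 log units; beyond the scatter). The step lies beyond the scatter but is modest in size, so this oxygen carries the larger group, with its three-membered ring, at a limited cost, and methoxy fits slightly better than cyclopropyloxy in this pair. No measured information here bears on why the number rises with this change.

From the compounds shown here alone, with only methyl and cyclopropyl on this oxygen, two points cannot define a trend, so it remains open whether an ethyl group, a longer chain, or a plain hydroxyl in place of the methoxy would raise the number further, lower it or leave it unchanged. Going by these compounds, it is also open whether an amine carried on a chain at this oxygen would be accepted, and whether the same methoxy to cyclopropyloxy change would give a similar step in compound 1, where the aromatic nitrogen carries hydrogen rather than methyl.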